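The source may report more compounds than this note shows. Statements on the series, on what has been measured and on what is new or still open speak of the compounds shown alone.

Measured so far in an ADME assay on RAW264.7 cells (Mus musculus) for cytotoxicity, with a stated time of 24 h; a lower number here means a stronger inhibitor, a higher number a weaker inhibitor:
- compound 1, `COc1ccc(-c2cc(-c3ccc4c(c3)CCCC4)nc(NCc3ccccc3)c2C#N)cc1OC`: compound 1 gives 4900 nM.
- compound 2, `CC(C)c1ccc(-c2cc(-c3ccc4c(c3)CCCC4)nc(NCc3ccccc3)c2C#N)cc1`: compound 2 gives > 50000 nM, which is a limit of the assay rather than a number.
- compound 3, `COc1ccc(-c2cc(-c3ccc4c(c3)CCCC4)nc(OCC(=O)NCc3ccccc3)c2C#N)cc1OC`: compound 3 gives 8400 nM.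

The change 4-isopropylphenyl in place of 3,4-dimethoxyphenyl on an aromatic carbon gives an at least 10-fold higher number from compound 1 to compound 2 (1.00 log units; beyond the scatter), reaching (the limit of > 50000 nM in this assay, at which 1 of the 3 values shown sits). The two cores differ by (benzylcarbamoyl)methoxy in place of benzylamino on an aromatic carbon, a step of a 1.7-fold higher number from compound 1 to compound 3 (0.23 log units; within the scatter). Compound 4, `CC(C)c1ccc(-c2cc(-c3ccc4c(c3)CCCC4)nc(OCC(=O)NCc3ccccc3)c2C#N)cc1`, is not yet measured; it carries the same kind of change from compound 3, (4-isopropylphenyl in place of 3,4-dimethoxyphenyl on an aromatic carbon). The surroundings differ only in that the place is meta to a (benzylcarbamoyl)methoxy group here, where in compound 1 it was meta to a benzylamino group (8 heavy atoms). A step of about an 8.3-fold higher number from compound 3 to compound 4 (0.92 log units; beyond the scatter) is expected, set beside an at least 10-fold higher number from compound 1 to compound 2 (1.00 log units; beyond the scatter); this expectation rests on compound 1 and its step of an at least 10-fold higher number from compound 1 to compound 2 (1.00 log units; beyond the scatter) to the limit. Compound 4 is therefore expected to give about 70000 nM, estimated between 20000 nM and 250000 nM, most likely again as a limit.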

Compound 4, half-maximal inhibitory concentration: 9900 nM
For compound 4 the middle estimate is 7.1-fold (0.85 log units) above the measured one; measured number outside the range, below it.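

On the core of compound 3, 4-isopropylphenyl in place of 3,4-dimethoxyphenyl gives a 1.2-fold higher number from compound 3 to compound 4 (0.07 log units; within the scatter), while (benzylcarbamoyl)methoxy in place of benzylamino, with 4-isopropylphenyl kept, gives an at least 5.0-fold lower number from compound 2 to compound 4 (0.70 log units; beyond the scatter). In this assay the change therefore does not carry from the core of compound 1 to the core of compound 3: the same change on two cores in this assay, an at least 10-fold higher number (1.00 log units; beyond the scatter) from compound 1 to compound 2 and a 1.2-fold higher number (0.07 log units; within the scatter) from compound 3 to compound 4, at least 8.6-fold (0.93 log units) apart, beyond the scatter of two such steps. Going by these compounds, compound 2 gives > 50000 nM, which is a limit and not a number, so the full size of this gap stays unknown, and two cores show nothing about how the change behaves on any other core.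

Still open, on these data alone, is whether the gap between cores persists with a phenyl group bearing an amine or a carboxylic acid in place of 3,4-dimethoxyphenyl. Also open, as far as these compounds go, is how a longer chain in place of the (benzylcarbamoyl)methoxy group would behave.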